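The source may hold more compounds than are shown below. What is called first, only, known or untested is meant among the compounds shown, and "the series" means these compounds.

Working notes on the series. In a functional assay on MCF7 cells (Homo sapiens) for antiproliferative activity, read by MTT assay, with a stated time of 3 days (a lower number here means a stronger inhibitor, a higher number a weaker inhibitor), compound 2 `CCCCCC#Cc1cn(C/C=C/CN2C(=O)c3ccccc3C2=O)c(=O)[nH]c1=O` gives 44000 nM. For the measured compounds named here, its only neighbour so far, compound 1 `CCCCCCCCC#Cc1cn(C/C=C/CN2C(=O)c3ccccc3C2=O)c(=O)[nH]c1=O`, gives 66000 nM, and the step of a 1.5-fold lower number from compound 1 to compound 2 (0.18 log units; within the scatter) lies within the scatter, so the two numbers cannot be told apart. Compound 3 `CCCCc1ccc(C#Cc2cn(C/C=C/CN3C(=O)c4ccccc4C3=O)c(=O)[nH]c2=O)cc1` carries 4-butylphenyl in place of pentyl on a triple-bonded carbon. Going by the values given here, no measured step exchanges a chain for an aromatic ring, and the one step in hand, hydrogen in place of propyl, stayed within the scatter. For compound 3 the expected step in this assay is a 1.5-fold lower number from compound 2 to compound 3 (0.17 log units; within the scatter), no larger than the scatter. Compound 3 is therefore estimated at 30000 nM, with a range of 10000 nM to 100000 nM.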

Compound 3, half-maximal inhibitory concentration: 44000 nM
Compound 3: middle estimate off by 1.5-fold (0.17 log units), on the low side, within the range that was stated.
By their numbers in this assay, from the lowest: compounds 2, 3 and 1 (each within the scatter of the next).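

In this assay, exchanging a chain for an aromatic ring on a triple-bonded carbon gives no change at the digits printed from compound 2 to compound 3 (within the scatter) and 4-butylphenyl in place of octyl gives a 1.5-fold lower number from compound 1 to compound 3 (0.18 log units; within the scatter) at the same place. This position therefore carries pentyl, octyl or 4-butylphenyl, the last with its six-membered aromatic ring, without a difference that can be told from the scatter. No evidence bearing on the reason for this is available.

The compounds shown leave open whether an amine, a carboxylic acid or an unsubstituted phenyl on this triple-bonded carbon would give a step beyond the scatter.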